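The compounds below may be only part of what the source reports. "The series", "measured", "known", "first", "only" and "open" are said of these compounds alone.

Measured in an in vivo ADME assay on the whole organism for pharmacokinetics, with Rattus norvegicus as the target, at a dose of 10 mg/kg by the oral route; a higher number here means more compound in the circulation at the dose given, a lower number less compound in the circulation:
compound 1, `CC1(COc2c(N3CCN(S(=O)(=O)Cc4ccc(N)cc4)CC3)cnn(-c3cccc(Cl)c3)c2=O)CC1`: 3490 nM
compound 2, `CC1(COc2c(N3CCN(S(=O)(=O)Cc4cccc(N)c4)CC3)cnn(-c3cccc(Cl)c3)c2=O)CC1`: 2570 nM
compound 3, `CC1(COc2c(N3CCN(S(=O)(=O)Cc4ccc(N)c(C(F)(F)F)c4)CC3)cnn(-c3cccc(Cl)c3)c2=O)CC1`: 719 nM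

Compound 3 sits lowest of the three in this assay: it is reached from compound 2 by a 3.6-fold lower number from compound 2 to compound 3 (0.55 log units; beyond the scatter) and from compound 1 by a 4.9-fold lower number from compound 1 to compound 3 (0.69 log units; beyond the scatter), both beyond the scatter, whereas a 1.4-fold lower number from compound 1 to compound 2 (0.13 log units; within the scatter) stays within it. Compound 4, `CCc1cc(CS(=O)(=O)N2CCN(c3cnn(-c4cccc(Cl)c4)c(=O)c3OCC3(C)CC3)CC2)ccc1N`, differs from compound 3 in one place: ethyl in place of trifluoromethyl on an aromatic carbon. For the measured compounds named here, no measured step exchanges trifluoromethyl for ethyl. Going by the values given here, the only step that touches this aromatic carbon is the entry of the trifluoromethyl, and because a 4.9-fold lower number from compound 1 to compound 3 (0.69 log units; beyond the scatter) is a modest drop, a partial return toward compound 1 is expected once that group leaves, so compound 4 is expected at a 2.1-fold higher number from compound 3 to compound 4 (0.32 log units; beyond the scatter) in this assay. Compound 4 is therefore estimated at 1500 nM, within 500 nM to 4500 nM.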

Compound 4, maximal plasma concentration: 4020 nM
Compound 4: middle estimate off by 2.7-fold (0.43 log units), on the low side, within the range that was stated.
By their numbers in this assay, from the lowest: compound 3; then compounds 2, 1 and 4 (each within the scatter of the next).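

In this assay, a substituent on this aromatic carbon ortho to an amino group does not in itself lower the number: ethyl gives a 5.6-fold higher number from compound 3 to compound 4 (0.75 log units; beyond the scatter) and so removes the drop seen with trifluoromethyl. Ethyl also shows a 1.2-fold higher number from compound 1 to compound 4 (0.06 log units; within the scatter) and a 1.6-fold higher number from compound 2 to compound 4 (0.19 log units; within the scatter) so that, among the compounds shown, only trifluoromethyl at this carbon stands apart. No measurement on hand explains the gap between ethyl and trifluoromethyl. As far as these compounds go, whether methyl, chlorine or a longer chain at this carbon would track ethyl or trifluoromethyl stays open.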